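The source may hold more compounds than are shown below. What is called first, only, known or untested is meant among the compounds shown, and "the series" means these compounds.

Compound 1 `CC(=O)OC[C@H]1O[C@@H](n2cc(CN3C(=O)/C(=C/c4ccc(N(C)C)cc4)c4ccccc43)nn2)[C@H](OC(C)=O)[C@@H](OC(C)=O)[C@@H]1OC(C)=O` gives 11200 nM in a functional assay on DU-145 cells (Homo sapiens) for cytotoxicity, read by sulforhodamine B assay, with a stated time of 48 h; on this read-out lower numbers stand for stronger inhibition and higher numbers for weaker inhibition. Compound 2 `CC(=O)OC[C@H]1O[C@@H](n2cc(CN3C(=O)/C(=C\c4ccc5ccccc5c4)c4ccccc43)nn2)[C@H](OC(C)=O)[C@@H](OC(C)=O)[C@@H]1OC(C)=O` gives > 100000 nM in this assay, which is a limit of the assay rather than a number.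

As far as these compounds go, compound 2 therefore stands at the limit (the limit of > 100000 nM in this assay, at which 1 of the 2 values shown sits), so its true potency is unknown beyond being weak. Going by the values given here, compound 3 `CC(=O)OC[C@H]1O[C@@H](n2cc(CN3C(=O)/C(=C/c4ccc5ccccc5c4)c4ccccc43)nn2)[C@H](OC(C)=O)[C@@H](OC(C)=O)[C@@H]1OC(C)=O` keeps every atom and bond of compound 2, and the only change is the two compounds have the same atoms and bonds and differ only in configuration as drawn: 1 of 6 stereo elements differ; a double bond is drawn Z in compound 2 and E in compound 3. Among the compounds with values here, no measured pair shows what this change in drawn geometry does here, so no size or direction of step can be read from the data. Compound 3 is expected to give 40000 nM in this assay, within 8000 nM to 200000 nM. The expected step of an at least 2.5-fold lower number from compound 2 to compound 3 (0.39 log units; beyond the scatter) stays uncertain, and a limit-only result remains likely.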

Compound 3, half-maximal inhibitory concentration: 43700 nM
Estimate against measurement, compound 3: 1.1-fold (0.04 log units) below, and the stated range covers the measured number.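

In this assay, the drawn geometry of the double bond alone changes the result, with an at least 2.2-fold lower number from compound 2 to compound 3 (0.35 log units; beyond the scatter): the fact that compounds 2 and 3 differ only in the configuration as drawn. As far as these compounds go, compound 2 gives a limit rather than a number, so the true size of that step stays unknown: the limit of > 100000 nM in this assay, at which 1 of the 3 values shown sits. Naphthalen-2-yl in place of 4-(dimethylamino)phenyl gives a 3.9-fold higher number from compound 1 to compound 3 (0.59 log units; beyond the scatter), so this position responds to both the group and its geometry.

From the compounds shown here alone, whether the 4-(dimethylamino)phenyl group responds to the same change in geometry remains open. So does the effect of a carboxylic acid on that ring, or of free hydroxyl groups in place of the acetyl groups.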